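The compounds below may be only part of what the source reports. "The series", "measured", "known", "first", "only" and "open" are said of these compounds alone.

For the measured compounds named here, in a functional assay on PC-12 cells (Rattus norvegicus) for cytotoxicity, read by MTT assay, with stated times of 2 h and 24 h, tested at 1 uM (on this read-out higher numbers stand for a stronger effect at the one concentration tested and lower numbers for a weaker effect), compound 1 `CC(C)c1ccc(-n2nc(-c3ccc(C(F)(F)F)cc3O)nc2-c2ccccc2O)cc1` gives 69.7%, the lower of the two numbers measured so far, though only within the scatter of its neighbour: compound 2 `Oc1cc(C(F)(F)F)ccc1-c1nc(-c2ccccc2O)n(-c2cccc(C(F)(F)F)c2)n1` gives 71.5%, and the step of a number 1.8 percentage points higher from compound 1 to compound 2 (within the scatter) falls inside the usual spread of repeated measurements, so the two compounds stand level. Compound 3 `Oc1cc(C(F)(F)F)ccc1-c1nc(-c2ccccc2O)n(-c2ccc(Cl)cc2Cl)n1` has not yet been measured. It differs from compound 1 in one place: 2,4-dichlorophenyl in place of 4-isopropylphenyl on an aromatic nitrogen. Going by the values given here, the one measured step that bears on this change replaced the same 4-isopropylphenyl on the same aromatic nitrogen with 3-(trifluoromethyl)phenyl, namely a number 1.8 percentage points higher from compound 1 to compound 2 (within the scatter), and that step stayed within the scatter. Because of a number 1.8 percentage points higher from compound 1 to compound 2 (within the scatter) a further swap of the group on this aromatic nitrogen is expected to leave the read-out essentially unchanged, so the expected step of a number 0.3 percentage points higher from compound 1 to compound 3 (within the scatter) should not exceed the scatter. Compound 3 is therefore estimated at 70%, with a likely range from 58% to 82%.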

Compound 3, a percentage reported as activity, at one concentration (the size of the read-out at that concentration, not a potency): 69%
Beside the measured number, compound 3's estimate is 1 percentage points above it; measured number inside the range.
By their numbers in this assay, from the lowest: compounds 3, 1 and 2 (each within the scatter of the next).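

Swapping the group on this aromatic nitrogen a second time again gives no change that stands out in this assay, with a number 0.7 percentage points lower from compound 1 to compound 3 (within the scatter) and a number 2.5 percentage points lower from compound 2 to compound 3 (within the scatter). For the compounds shown here, the position has now carried 4-isopropylphenyl, 3-(trifluoromethyl)phenyl and 2,4-dichlorophenyl, and the three compounds stand level, even though chlorine enters here for the first time. No measurement at hand explains why these groups give the same result.

From the compounds shown here alone, all three groups are substituted phenyl rings, so it remains open whether something of a different kind on this nitrogen, such as a carboxylic acid, an amine or a longer alkyl chain, would move the number. With only one concentration shown, these numbers also say nothing about potency.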